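This account rests on a few compounds, and the source may have more. Where it says the series, first, only, none or still open, it means among the compounds named here.

Measured in a functional assay on the whole organism with Mus musculus as the target; a higher number here means that more compound is needed for the effect, a lower number that less compound is needed:
compound 1 `Cc1c(C)c2c(c(C)c1N)CC(C)(C)O2`: 7.8 mg/kg
compound 2 `Cc1cc2c(c(C)c1N)CC(C)(C)O2`: 16.3 mg/kg
compound 3 `Cc1c(C)c2c(c(N)c1N)CC(C)(C)O2`: > 50 mg/kg (a limit of the assay, not a number)

Compound 2, at 16.3 mg/kg, holds the higher of the two actual numbers. Compound 4 `CC(C)=Cc1c(C)c(N)c(C)c2c1OC(C)(C)C2` differs from it by 2-methylprop-1-en-1-yl in place of hydrogen on an aromatic carbon, with 2-methylprop-1-en-1-yl in place of hydrogen on an aromatic carbon, the carbon that carries methyl in compound 1. The closest evidence is therefore a 2.1-fold higher number from compound 1 to compound 2 (0.32 log units; beyond the scatter), a modest step beyond the scatter. The other step, an at least 6.4-fold higher number from compound 1 to compound 3 (0.80 log units; beyond the scatter), concerns amino on a different carbon and bears only loosely. Filling this carbon should lower the number in this assay somewhat, although no group of this size has been tested there. The expected change is a 1.6-fold lower number from compound 2 to compound 4 (0.21 log units; within the scatter). For compound 4 the estimated value is 10 mg/kg, with an expected range of 3 mg/kg to 35 mg/kg.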

Compound 4, dose for 50% inhibition: 21.9 mg/kg
Beside the measured number, compound 4's estimate is 2.2-fold (0.34 log units) below it; the range from low to high includes it.
By their numbers in this assay, from the lowest: compound 1; then compounds 2 and 4 (each within the scatter of the next). At a limit, above all of these: compound 3.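

this assay shows a 1.3-fold higher number from compound 2 to compound 4 (0.13 log units; within the scatter) and so puts 2-methylprop-1-en-1-yl on this aromatic carbon level with hydrogen. Methyl on the same carbon stands apart, with a 2.8-fold higher number from compound 1 to compound 4 (0.45 log units; beyond the scatter) as the measure, so filling this carbon does not by itself give the lower number seen with methyl. Nothing at hand accounts for this difference between the groups. From the compounds shown here alone, whether ethyl, methoxy or a saturated isobutyl chain on this carbon would behave like methyl or like 2-methylprop-1-en-1-yl stays open.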